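A Sulfoximine in Place of the Carbinol Chain

A few compounds are considered here, and "the series" means these few. Any claim that something is new, unique, unknown or untested is made for them only; others in the source may bear on it.

Compound 1 `CC#CCC(O)(c1ccc(N2CCN(S(=O)(=O)c3ccc(N)nc3)C[C@@H]2C#CC)cc1)C(F)(F)F`: 5 nM
Compound 2 `CC#C[C@H]1CN(S(=O)(=O)c2ccc(N)nc2)CCN1c1ccc(C(O)(CC#N)C(F)(F)F)cc1`: 28 nM

In an assay on isolated protein for inhibition of glucokinase regulatory protein (Homo sapiens), read by AlphaScreen, with stated times of 20 min and 4 h (on this read-out higher numbers stand for weaker inhibition and lower numbers for stronger inhibition), compound 1 gives 5 nM, and compound 2 gives 28 nM, the higher of the two numbers; the step of a 5.6-fold higher number from compound 1 to compound 2 (0.75 log units; beyond the scatter) lies beyond the scatter. Compound 3 `CC#C[C@H]1CN(S(=O)(=O)c2ccc(N)nc2)CCN1c1ccc(S(=N)(=O)C2CC2)cc1` is not yet measured. It differs from compound 2 by a group of 6 heavy atoms (3 carbon, 1 nitrogen, 1 oxygen, 1 sulfur; one three-membered non-aromatic ring of carbon only) in place of a group of 9 heavy atoms (4 carbon, 1 nitrogen, 1 oxygen, 3 fluorine; no ring), on an aromatic carbon. Among the measured compounds shown here, the only measured step altered the same region but kept the carbinol chain, so no measured step bears directly on this exchange. For the measured compounds named here, with that single modest step as the only guide, compound 3 is expected to show a 1.1-fold higher number from compound 2 to compound 3 (0.03 log units; within the scatter). The estimate for compound 3 is 30 nM, within 8 nM to 150 nM.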

Compound 3, half-maximal inhibitory concentration: 256 nM
Compound 3: middle estimate off by 8.5-fold (0.93 log units), on the low side, and the stated range ends below it.
By their numbers in this assay, from the lowest: compound 1; then compound 2; then compound 3.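

In this assay, putting the sulfoximine group with its three-membered carbon ring on this aromatic carbon gives a 9.1-fold higher number from compound 2 to compound 3 (0.96 log units; beyond the scatter) and, measured against the propynyl carbinol, a 51-fold higher number from compound 1 to compound 3 (1.71 log units; beyond the scatter) in the same direction. The earlier compounds shown here changed only the end of the carbinol chain, whereas compound 3 shows that replacing the whole chain, trifluoromethyl and hydroxyl included, carries a cost beyond the scatter. Nothing available here explains this shift.

Whether the sulfoximine itself or the missing trifluoromethyl carbinol accounts for the higher number remains open. So does whether a methyl group or a longer chain on the sulfur in place of the three-membered ring would change the number.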